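A few compounds are considered here, and "the series" means these few. Any claim that something is new, unique, unknown or untested is made for them only; others in the source may bear on it.

Measured in a functional assay on RXF 393 cells (Homo sapiens) for inhibition, read by sulforhodamine B assay, with a stated time of 48 h; on this read-out higher numbers stand for weaker inhibition of growth and lower numbers for stronger inhibition of growth:
- compound 1 `COc1cc(-c2nn(-c3cccc(NC(=O)Nc4cccc(C(F)(F)F)c4)c3)cc2-c2ccncc2)ccc1Cl`: 777 nM
- compound 2 `COc1cc(-c2nn(-c3cccc(NC(=O)c4ccc(Cl)c(C(F)(F)F)c4)c3)cc2-c2ccncc2)ccc1Cl`: 1760 nM

Compound 2 has the higher of these two numbers, which here means the weaker inhibition of growth. Compound 3 `COc1cc(-c2nn(-c3cccc(NC(=O)c4ccccc4)c3)cc2-c2ccncc2)ccc1Cl` has not yet been measured. It differs from compound 2 in one place, on a carbonyl carbon whose other neighbour is an amide-type nitrogen, with phenyl in place of 4-chloro-3-(trifluoromethyl)phenyl (phenyl in place of 4-chloro-3-(trifluoromethyl)phenyl on a carbonyl carbon). Within the data shown here, only one measured step touches that carbonyl carbon, a 2.3-fold higher number from compound 1 to compound 2 (0.36 log units; beyond the scatter), and it is modest. That step swaps different groups, so it is only a rough guide to size. Among the measured compounds shown here, both measured compounds carry a trifluoromethyl group on this side and compound 3 has none, so no measured compound shows what a bare phenyl does. A modest or somewhat larger move toward a higher number in this assay is therefore expected, though the direction remains a judgement. The expected change is a 2.0-fold higher number from compound 2 to compound 3 (0.30 log units; within the scatter). For compound 3 the estimated value is 3500 nM, with an expected range from 1300 nM to 10000 nM.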

Compound 3, concentration for 50% growth inhibition: 646 nM
Beside the measured number, compound 3's estimate is 5.4-fold (0.73 log units) above it, and the stated range ends above it.
By their numbers in this assay, from the lowest: compounds 3 and 1 (each within the scatter of the next); then compound 2.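

In this assay, phenyl in place of 4-chloro-3-(trifluoromethyl)phenyl on the carbonyl carbon gives a step that runs against the earlier picture (a 2.7-fold lower number from compound 2 to compound 3 (0.44 log units; beyond the scatter)), so on this pair the larger substituted ring is not needed for inhibition of growth, and the bare ring does better than the substituted one. Phenyl in place of (3-(trifluoromethyl)phenyl)amino on the same carbonyl carbon gives a step that does not separate the two compounds (a 1.2-fold lower number from compound 1 to compound 3 (0.08 log units; within the scatter)), which shows that a compound with no trifluoromethyl group on this side can match one that has it. Nothing available explains why the smaller group gives the stronger result in this pair.

Chlorine and trifluoromethyl leave together in the step from the substituted ring to phenyl, which leaves open whether one of them alone accounts for the difference. Also open, as far as these compounds go, is how this carbonyl position would respond to a phenyl ring carrying a single chlorine, a methoxy group or an amine, or to a longer chain or a carboxylic acid in place of the ring.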